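The source may hold more compounds than are shown below. What is called first, only, known or untested is meant among the compounds shown, and "the series" means these compounds.

Working notes on the series. In a functional assay on HUVEC cells (Homo sapiens) for inhibition, with a stated time of 4 days (on this read-out higher numbers stand for weaker inhibition and lower numbers for stronger inhibition), compound 1 (`Cc1cc(OCc2cccc(C#N)c2)ccc1Cl`) gives 11000 nM and compound 2 (`COc1ccc(C(N)=O)cc1/C=C/c1ccc(C(C)(C)C)cc1`) gives 370 nM as the lower of the two numbers, a gap beyond the scatter. Going by the values given here, the two compounds are not linked by a change in one place, so no measured step guides what follows. Compound 3 (`COc1ccc(C(N)=O)cc1/C=C/c1ccc(F)cc1`) is otherwise the same as compound 2 but has fluoro in place of tert-butyl on an aromatic carbon, para to a large group (fluoro in place of tert-butyl on an aromatic carbon). Starting from compound 2 at 370 nM and with no measured step for this change, weaker inhibition beyond the scatter is expected in this assay as a higher number. The expected change is a 6.8-fold higher number from compound 2 to compound 3 (0.83 log units; beyond the scatter) on this estimate. Compound 3 is estimated at 2500 nM for now (expected range 600 nM to 10000 nM).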

Compound 3, half-maximal inhibitory concentration: 2100 nM
Compound 3: middle estimate off by 1.2-fold (0.08 log units), on the high side; the measured number falls inside the stated range.
By their numbers in this assay, from the lowest: compound 2; then compound 3; then compound 1.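

This position on the aromatic ring, para to a large group, responds to the group it carries: in this assay, fluoro in place of tert-butyl gives a 5.7-fold higher number from compound 2 to compound 3 (0.75 log units; beyond the scatter). Inhibition is still measured with fluoro, so tert-butyl is not required for a reading in this assay, although compound 2 holds the lower number of the pair. Nothing available accounts for the difference between the two groups.

Going by these compounds, whether methyl, chloro, methoxy, an amine or a carboxylic acid at this position would fall nearer compound 2, nearer compound 3 or outside that span remains open. With only tert-butyl and fluoro compared here, this single step gives no trend across groups at this position and says nothing about changes elsewhere on the shared core.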